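This account rests on a few compounds, and the source may have more. Where it says the series, first, only, none or still open, it means among the compounds named here.

Compound 3, with the structure `C[C@@H](Cn1ccc(-c2ccc(C#N)c(Cl)c2)n1)Nc1cccnc1`, sits in an ADME assay on PC-3 cells (Homo sapiens) for cytotoxicity, read by CCK-8 assay, with a stated time of 6 days (a higher number here means a weaker inhibitor, a lower number a stronger inhibitor), at > 30000 nM, which is a limit of the assay rather than a measured number. Its two neighbours in the set are no different in this respect. Compound 1 `COC(=O)/C=C/C(=O)N[C@@H](C)Cn1ccc(-c2ccc(C#N)c(Cl)c2)n1` gives > 30000 nM in this assay, again a limit. Compound 2 `C[C@@H](Cn1ccc(-c2ccc(C#N)c(Cl)c2)n1)NS(=O)(=O)c1cccnc1` gives > 30000 nM in this assay, also a limit. Because all three values sit at the limit of > 30000 nM in this assay, at which 3 of the 3 values shown sit, the steps among them cannot be read: from compound 1 to compound 2 the step is a step that the two limits leave unreadable from compound 1 to compound 2, from compound 1 to compound 3 it is a step that the two limits leave unreadable from compound 1 to compound 3, and from compound 2 to compound 3 it is a step that the two limits leave unreadable from compound 2 to compound 3. The series thus shows three groups on the amine nitrogen, an acyl, a sulfonyl and an aryl, none of which brings the value into the readable range.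

Compound 4 `Cc1ccnc(N[C@@H](C)Cn2ccc(-c3ccc(C#N)c(Cl)c3)n2)n1` differs from compound 3 in one place: 4-methylpyrimidin-2-yl in place of pyridin-3-yl on an amine nitrogen. Within the data shown here, no measured step speaks to this exchange, and nothing among the three measured compounds suggests a move out of the limit region. The step from compound 3 to compound 4 is therefore expected to be a number no higher from compound 3 to compound 4 (the limit leaves the size open), in effect none that the assay can resolve. Compound 4 is accordingly expected to give 30000 nM, with a range from 15000 nM to 60000 nM, and most probably only a limit will be reported.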

Compound 4, half-maximal inhibitory concentration: > 30000 nM
Compound 4: no number, only a limit; the forecaster's own chance of this, stated with the estimate: 85%; the middle value lies on the limit itself.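

The steps to compound 4 from compound 1, compound 2 and compound 3 cannot be read, because all four compounds share one limit: the limit of > 30000 nM in this assay, at which 4 of the 4 values shown sit.

The compounds shown leave open whether any group on the amine nitrogen brings the value in this assay into the readable range, and how far each compound lies beyond the limit.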